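The compounds below may be only part of what the source reports. "The series", "measured", "known", "first", "only" and "open" are said of these compounds alone.

Measured so far in a functional assay on MOLT-4 cells (Homo sapiens) for cytotoxicity, read by sulforhodamine B assay, with a stated time of 48 h, tested at 0.01 uM; on this read-out higher numbers stand for a weaker effect at the one concentration tested and lower numbers for a stronger effect:
compound 1, `COc1cc(-c2cc(/C=C/C(=O)c3ccc(Cl)c(Cl)c3)[nH]n2)cc(OC)c1OC`, gives 98%;
compound 2, `COc1ccc(C(=O)/C=C/c2cc(-c3cc(OC)c(OC)c(OC)c3)n[nH]2)cc1OC`, gives 102%.

On these two numbers compound 2 stands level with compound 1: the gap between them lies within the scatter, so neither is separated from the other, and both sit at the weak end of this assay at this concentration. Going by the values given here, the one measured step, a number 4 percentage points higher from compound 1 to compound 2 (within the scatter), exchanged the aryl group on the carbonyl carbon and moved nothing beyond the scatter.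

Compound 3, `COc1cc(C(=O)/C=C/c2cc(-c3cc(OC)c(OC)c(OC)c3)n[nH]2)cc(OC)c1OC`, differs from compound 2 by methoxy in place of hydrogen on an aromatic carbon. Among the compounds with values here, no measured step alters the count of methoxy groups on that ring, so the only guide is the flat step from compound 1 to compound 2 and the weak level of both. The expectation for compound 3 is therefore a step of a number 2 percentage points lower from compound 2 to compound 3 (within the scatter), nothing beyond the scatter. Compound 3 is estimated at 100%, with a range of 86% to 112%.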

Compound 3, a percentage reported as activity, at one concentration (the size of the read-out at that concentration, not a potency): 104%
Beside the measured number, compound 3's estimate is 4 percentage points below it; low and high end bracket the measured number.
By their numbers in this assay, from the lowest: compounds 1, 2 and 3 (each within the scatter of the next).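

In this assay, methoxy in place of hydrogen on an aromatic carbon, ortho to a methoxy group, gives a number 2 percentage points higher from compound 2 to compound 3 (within the scatter). This is the only step shown that changes the count of methoxy groups on the aryl ring attached to the carbonyl carbon, and at this concentration that change does not separate the two compounds, which both remain at the weak end of the read-out. No evidence bearing on this result is available.

The single low concentration leaves open whether compound 2 and compound 3 would separate at higher concentrations. Also open, on these data alone, is whether a group of a different kind at this position, such as an amine or a carboxylic acid, would move the read-out beyond the scatter.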